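A few compounds are considered here, and "the series" means these few. Any claim that something is new, unique, unknown or untested is made for them only; others in the source may bear on it.

Measured in an assay on isolated protein for inhibition of leukotriene B4 receptor 1 (Homo sapiens), tested at 10 uM; a lower number here means less inhibition, a higher number more inhibition at the concentration tested (going by the name of the read-out):
Compound 1 `CCc1cc(C(C)=O)c(O)cc1OCCCCC#N`: 92%
Compound 2 `CCc1cc(C(C)=O)c(O)cc1OCCCC(C)(C)C(=O)O`: 89%
Compound 3 `CCc1cc(C(C)=O)c(O)cc1OCCCC(C)(C)C(N)=O`: 92%

Compound 3 stands level with compound 1 at the digits given, and the step of a number 3 percentage points higher from compound 2 to compound 3 (within the scatter) also lies within the scatter, so the three values cannot be told apart. Compound 4 `CCc1cc(C(C)=O)c(O)cc1OCCCC(C)(C)c1nnn[nH]1` is compound 3 with 1H-tetrazol-5-yl in place of carbamoyl on a saturated chain carbon bound to three saturated chain carbons. Within the data shown here, the steps that bear on this, no change at the digits printed from compound 1 to compound 3 (within the scatter) and a number 3 percentage points higher from compound 2 to compound 3 (within the scatter), both swap the group at the chain end and both stay within the scatter, so the account expects no step beyond the scatter in this assay for compound 4. Compound 4 is therefore estimated at 90%, between 80% and 97%, which means an expected step of a number 2 percentage points lower from compound 3 to compound 4 (within the scatter).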

Compound 4, a percentage reported as inhibition, at one concentration (the size of the read-out at that concentration, not a potency): 100%
The estimate for compound 4 lay 10 percentage points below the measured number, outside the stated range (above it).
By their numbers in this assay, from the lowest: compounds 2, 1, 3 and 4 (each within the scatter of the next, the first and the last beyond it).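

In this assay the 1H-tetrazol-5-yl group at the chain end gives the only step beyond the scatter among these compounds: in place of carboxy it gives a number 11 percentage points higher from compound 2 to compound 4 (beyond the scatter) (modest). In place of carbamoyl it gives a number 8 percentage points higher from compound 3 to compound 4 (within the scatter) and against the nitrile-ended chain a number 8 percentage points higher from compound 1 to compound 4 (within the scatter) so compound 4 separates from compound 2 alone. Nothing shown gives a reason for this step.

The compounds shown leave open how a methyl ester or a sulfonamide at the same chain end would read. They also leave open what a longer chain carrying the 1H-tetrazol-5-yl group would do.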